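The compounds below may be only part of what the source reports. "The series", "measured", "known", "first", "only" and "open" are said of these compounds alone.

Of the compounds shown here, three of one shared core have been measured in an ADME assay on A549 cells (Homo sapiens) for cytotoxicity, read by MTT assay; a higher number here means that more compound is tolerated, a lower number that less compound is tolerated. Compound 1 `CCCCC#Cc1c[nH]c(=O)[nH]c1=O` gives 250000 nM, compound 2 `C[Si](C)(C)C#Cc1c[nH]c(=O)[nH]c1=O` gives 268000 nM, and compound 3 `O=c1[nH]cc(C#CC(O)c2ccccc2)c(=O)[nH]1` gives 237000 nM. Compound 3 thus holds the lowest of the three numbers, but its gaps to compound 1 and to compound 2 are within the scatter, so the three cannot be ordered. Among the measured compounds shown here, the one measured step, a 1.1-fold higher number from compound 1 to compound 2 (0.03 log units; within the scatter), also stays within the scatter. Compound 4 `O=c1[nH]c(=O)n([C@@H]2O[C@H](CO)[C@@H](O)[C@H]2O)cc1C#CC(O)c1ccccc1` carries 3,4-dihydroxy-5-(hydroxymethyl)oxolan-2-yl in place of hydrogen on an aromatic nitrogen. For the measured compounds named here, no measured step touches this position, and nothing in the data speaks for a shift beyond the scatter. Compound 4 is therefore expected to show a 1.0-fold higher number from compound 3 to compound 4 (0.01 log units; within the scatter), with an estimate of 240000 nM (range 110000 nM to 500000 nM).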

Compound 4, half-maximal cytotoxic concentration: 34200 nM
Estimate against measurement, compound 4: 7.0-fold (0.85 log units) above, and the stated range ends above it.
By their numbers in this assay, from the lowest: compound 4; then compounds 3, 1 and 2 (each within the scatter of the next).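

Among the compounds shown here, the entry of 3,4-dihydroxy-5-(hydroxymethyl)oxolan-2-yl in place of hydrogen on an aromatic nitrogen brings a 6.9-fold lower number from compound 3 to compound 4 (0.84 log units; beyond the scatter) in this assay and is the first change here to lie beyond the scatter. This aromatic nitrogen therefore responds to substitution, whereas the change on the triple-bonded carbon from compound 1 to compound 2 stayed within the scatter. Nothing available accounts for the shift.

On these data alone, it remains open whether a methyl group or a hydroxyethyl chain on this nitrogen would lower the number as well. As far as these compounds go, whether 3,4-dihydroxy-5-(hydroxymethyl)oxolan-2-yl would act alike on compound 1 or compound 2 also remains open.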